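Swapping Ethyl for Cyclopropyl in a Permeability Series

The source may report more compounds than this note shows. Statements on the series, on what has been measured and on what is new or still open speak of the compounds shown alone.

Compound 1 `CCCN(Cc1ccc(OCCN2C(=O)CCC2=O)c(C)c1)[C@@H](CC(=O)O)c1ccc(Cl)cc1` has been tested in an ADME assay on Caco-2 cells (Homo sapiens) for permeability, read by LC-MS, with a stated time of 2 h (a lower number here means that the compound crosses the layer more slowly, a higher number that the compound crosses the layer faster), where compound 1 gives 9.3 nm/s. That is the higher of the two numbers available: compound 3 `CCN(Cc1ccc(OCCN2C(=O)CCC2=O)c(C)c1)C(CC(=O)O)c1ccc(Cl)cc1` gives 3.9 nm/s, a gap beyond the usual scatter. Compound 2 `CCCN(Cc1ccc(OCCN2C(=O)CCC2=O)c(C)c1)[C@H](CC(=O)O)c1ccc(Cl)cc1` offers no comparison, since compound 2 stands at "not determined" (no result reported). What ties it to compound 1 is the fact that compounds 1 and 2 differ only in the configuration as drawn.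

Next comes compound 4 `Cc1cc(CN(CC2CC2)[C@@H](CC(=O)O)c2ccc(Cl)cc2)ccc1OCCN1C(=O)CCC1=O`, which is still unmeasured. Its change from compound 1 is cyclopropyl in place of ethyl on a saturated chain carbon bound to an amine nitrogen. Cut one bond further out, the same difference reads propyl to cyclopropylmethyl. Going by the values given here, no measured pair shows this change on its own, so the best anchor is compound 1 at 9.3 nm/s. No step beyond the scatter is expected in this assay, and the estimated move is a 1.2-fold higher number from compound 1 to compound 4 (0.07 log units; within the scatter). For compound 4 the expected value is 11 nm/s, within an estimated range of 4.5 nm/s to 25 nm/s.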

Compound 4, apparent permeability: 7.3 nm/s
Compound 4: the middle estimate sits 1.5-fold (0.18 log units) above what was measured; the range from low to high includes it.
By their numbers in this assay, from the lowest: compounds 3, 4 and 1 (each within the scatter of the next, the first and the last beyond it).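

Going by these compounds alone, this is the first pair that isolates the change, and it gives a 1.3-fold lower number from compound 1 to compound 4 (0.11 log units; within the scatter) in this assay. At this position on the shared core, then, going from ethyl to cyclopropyl, or from propyl to cyclopropylmethyl when cut one bond further out, brings in a three-membered ring of carbon without a step that stands out from the scatter in this single pair. Nothing available here bears on why the two numbers lie so close.

As far as these compounds go, whether the same holds for a longer chain such as butyl, a larger ring such as cyclohexyl, or a chain carrying a hydroxyl group at this position remains open. One pair in one configuration as drawn also cannot show whether the change would read alike on a different core.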